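The source may hold more compounds than are shown below. What is called first, only, known or untested is meant among the compounds shown, and "the series" means these compounds.

Three thiosemicarbazones built on one shared core appear here. Compound 1 `CC(C)NC(=S)N/N=C\c1c[nH]c2ccccc12` carries isopropyl on the amide-type nitrogen, compound 2 `CCCNC(=S)N/N=C\c1c[nH]c2ccccc12` carries propyl there, and compound 3 `Cc1ccc(NC(=S)N/N=C\c2c[nH]c3ccccc23)cc1` is the one still to be measured. In an ADME assay on KB cells (Homo sapiens) for cytotoxicity, read by MTT assay, with a stated time of 44 h (on this read-out higher numbers stand for weaker inhibition and lower numbers for stronger inhibition), compound 1 gives only a limit, > 100000 nM. Compound 2 in this assay likewise gives only a limit, > 100000 nM. The step that the two limits leave unreadable from compound 1 to compound 2 therefore cannot be read, since both values rest at the limit of > 100000 nM in this assay, at which 2 of the 2 values shown sit. Among the measured compounds shown here, compound 2 thus stands at the limit rather than at a number, and the one further value shown is a limit as well.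

The change to compound 3 is 4-methylphenyl in place of propyl on an amide-type nitrogen. For the measured compounds named here, only the step from compound 1 to compound 2 bears on it, and its size is unreadable; moreover that step swapped one chain for another, whereas here an aromatic ring enters in place of a chain. Going by the values given here, no measured step therefore says how large a step to expect in this assay, in either direction. Compound 3 is expected to remain near the limit, with an estimated step of an at least 1.2-fold lower number from compound 2 to compound 3 (0.09 log units; that floor lies within the scatter). Compound 3 is estimated at 80000 nM, within a range from 10000 nM to 300000 nM.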

Compound 3, half-maximal inhibitory concentration: > 100000 nM
Compound 3 gave a limit, no number (the forecaster's own chance of this, stated with the estimate: 65%); middle value at least 1.2-fold (0.09 log units) from the limit.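

Compound 3 joins compound 1 and compound 2 at a limit rather than a number, so no step among these three compounds can be read: the limit of > 100000 nM in this assay, at which 3 of the 3 values shown sit.

The compounds shown leave open whether any group on the amide-type nitrogen of the shared core gives a number in this assay, and how large a step there could be.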